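A few compounds are considered here, and "the series" means these few. Any claim that something is new, unique, unknown or untested is made for them only; others in the source may bear on it.

Working notes on the series. Compound 1 `COC(=O)C[C@@H](O)[C@@H]1O[C@H](c2ccccc2)[C@@H](O)[C@@H]1O` and compound 2 `COC(=O)C[C@H](O)[C@@H]1O[C@@H](c2ccccc2)[C@@H](O)[C@@H]1O` are open-chain hydroxy esters on the same oxygenated ring; in a functional assay on MCF7 cells (Homo sapiens) for antiproliferative activity, read by sulforhodamine B assay, with a stated time of 48 h (a lower number here means a stronger inhibitor, a higher number a weaker inhibitor), compound 1 reads "not active" (no number reported), and in this assay compound 2 reads "not active" (no number reported), which is noted alongside (the fact that compounds 1 and 2 differ only in the configuration as drawn). Among the compounds with values here, compound 3 `O=C1C=C[C@@H]2O[C@H](c3ccccc3)[C@@H](O)[C@@H]2O1` carries the fused unsaturated lactone instead; in this assay compound 3 gives 124000 nM, the only number in hand, weak as it is. Compound 4 `O=C1C=C[C@H]2O[C@@H](c3ccccc3)[C@H](O)[C@H]2O1` is its mirror image: the two compounds have the same atoms and bonds and differ only in configuration as drawn: 4 of 4 stereo elements differ (all stereocentres are inverted: mirror images); a stereocentre at a saturated ring carbon is drawn S in compound 3 and R in compound 4; a stereocentre at a saturated ring carbon is drawn R in compound 3 and S in compound 4; a stereocentre at a saturated ring carbon is drawn R in compound 3 and S in compound 4; a stereocentre at a saturated ring carbon is drawn S in compound 3 and R in compound 4. No measured step exists between any two of these compounds. For an inversion of all stereocentres a step within the scatter, or at most a modest one in either direction, is expected, a 1.2-fold higher number from compound 3 to compound 4 (0.08 log units; within the scatter). Compound 4 is therefore estimated at 150000 nM, with a range of 40000 nM to 600000 nM.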

Compound 4, half-maximal inhibitory concentration: 100000 nM
Compound 4: the middle estimate sits 1.5-fold (0.18 log units) above what was measured; the range from low to high includes it.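

In this assay the series now has its first numeric step, a 1.2-fold lower number from compound 3 to compound 4 (0.09 log units; within the scatter), so inverting all four stereocentres of the fused unsaturated lactone leaves the read-out within the scatter. The earlier stereo pair offered no such reading, as both of its members read "not active" without a number: the fact that compounds 1 and 2 differ only in the configuration as drawn. On the lactone, the same kind of change can now be sized: the fact that compounds 3 and 4 differ only in the configuration as drawn.

How far the lactone stands from the open-chain hydroxy esters cannot be sized, as those esters carry no number. Also open, from the compounds shown here alone, is how the lactone would read with an amine or a carboxylic acid in place of phenyl.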